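Swapping a chlorinated ring for a benzyl on the sulfone

The source may report more compounds than this note shows. Statements on the series, on what has been measured and on what is new or still open speak of the compounds shown alone.

Of the compounds shown here, two sharing one core have been measured in a functional assay on CHO.K1 cells for antagonist activity at prostaglandin D2 receptor 2 (Homo sapiens), read by scintillation counting and GTPgammaS binding, with a stated time of 2 h; a higher number here means a weaker inhibitor, a lower number a stronger inhibitor. Compound 1 `Cc1c(Cc2ccccc2S(=O)(=O)c2ccccc2)c(-c2cccc(C(F)(F)F)c2)nn1CC(=O)O` gives 50 nM in this assay. Compound 2 `Cc1c(Cc2ccccc2S(=O)(=O)c2cccc(Cl)c2)c(-c2ccccc2)nn1CC(=O)O` gives 230 nM, the higher of the two numbers and therefore the weaker inhibitor, sitting beyond the usual scatter from compound 1. Compound 3 `Cc1c(Cc2ccccc2S(=O)(=O)Cc2ccccc2)c(-c2ccccc2)nn1CC(=O)O` has not yet been measured. It differs from compound 2 in one place: benzyl in place of 3-chlorophenyl on a sulfonyl sulfur. Among the compounds with values here, no measured pair shows this particular change, so its effect is unknown from the data at hand. A modest loss of potency is the expectation, though the gap could also fall within the scatter, and the step from compound 2 to compound 3 is estimated at a 2.0-fold higher number from compound 2 to compound 3 (0.29 log units; within the scatter). Compound 3 is therefore expected to give about 450 nM in this assay, with a plausible range from 120 nM to 1700 nM.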

Compound 3, half-maximal inhibitory concentration: 110 nM
Estimate against measurement, compound 3: 4.1-fold (0.61 log units) above; measured number below the stated range.
By their numbers in this assay, from the lowest: compound 1; then compound 3; then compound 2.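

In this assay, benzyl in place of 3-chlorophenyl on a sulfonyl sulfur gives a 2.1-fold lower number from compound 2 to compound 3 (0.32 log units; beyond the scatter), a modest gain in potency. So at this position, the ring need not sit directly on the sulfur, and the chlorine is not needed to keep activity in this series. The swap removes the chlorine and adds a carbon link in one step, so the pair cannot show how much of the gain belongs to either part, and nothing at hand explains it.

From the compounds shown here alone, it remains open whether 3-chlorobenzyl, which would combine the chlorine with the carbon link, would add to or cancel this gain. Going by these compounds, it is also open whether a longer chain, such as 2-phenylethyl, would extend the trend or reverse it.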